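The source may report more compounds than this note shows. Statements on the series, on what has been measured and on what is new or still open speak of the compounds shown alone.

In an ADME assay on HepG2 cells (Homo sapiens) for cytotoxicity, read by resazurin assay, with a stated time of 48 h (a lower number here means that less compound is needed, a higher number that more compound is needed for the effect), the measured compounds read as follows:

- Compound 1 `O=C(Nc1ccc(F)c(-c2nc3ncc(-c4ccc(F)c(F)c4)cc3[nH]2)c1)N1CCCC1` gives > 50000 nM as a limit.
- Compound 2 `O=C(Nc1ccc(F)c(-c2nc3ncc(-c4ccc(F)cc4F)cc3[nH]2)c1)N1CCCC1` gives 32400 nM as a true number.
- Compound 3 `Cc1nc(C)c(C(=O)Nc2ccc(F)c(-c3nc4ncc(-c5cccnc5Cl)cn4n3)c2)o1` gives > 50000 nM as a limit.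

Compound 2 is the only one here with a true number; the other two readings are limits (the limit of > 50000 nM in this assay, at which 2 of the 3 values shown sit).

Compound 4 `O=C(Nc1ccc(F)c(-c2nc3ncc(-c4cccc(F)c4F)cc3[nH]2)c1)N1CCCC1` carries 2,3-difluorophenyl in place of 2,4-difluorophenyl on an aromatic carbon. Among the compounds with values here, the one measured step that bears on this is also a swap between difluorophenyl groups, and its size is known only as a floor (an at least 1.5-fold lower number from compound 1 to compound 2 (0.18 log units; that floor lies within the scatter)). Resting on that step to compound 2, no change beyond the scatter is expected in this assay, in either direction. The estimated step is a 1.1-fold higher number from compound 2 to compound 4 (0.05 log units; within the scatter) and it would be too small to read as a real difference. The expected value for compound 4 is 36000 nM with an estimated range from 18000 nM to 50000 nM as the upper end.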

Compound 4, half-maximal effective concentration: > 50000 nM
Compound 4 ended at the assay's limit; the forecaster's own chance of this, stated with the estimate: 35%; middle value at least 1.3-fold (0.14 log units) away from the limit.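

At this position, 2,3-difluorophenyl in place of 2,4-difluorophenyl gives an at least 1.5-fold higher number from compound 2 to compound 4 (0.18 log units; that floor lies within the scatter) in this assay, so this change in fluorine pattern cannot yet be told apart from no change. The step between compound 1 and compound 4 cannot be read, since both readings are limits. Compound 2 alone has a true number, and the other compounds rest on a single ceiling: the limit of > 50000 nM in this assay, at which 3 of the 4 values shown sit.

On these data alone, how far compound 1 and compound 4 lie beyond that ceiling stays open. So does the effect of plain phenyl, or of a phenyl carrying an amine or a carboxylic acid, at this position.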